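The source may report more compounds than this note shows. Statements on the series, on what has been measured and on what is new or still open speak of the compounds shown alone.

Measured compounds:
compound 1 `Nc1ccccc1NC(=O)c1ccc(CNCc2nc(-c3ccc(F)cc3)no2)cc1` gives 2950 nM;
compound 2 `Nc1ccccc1NC(=O)c1ccc(CNCc2nc(-c3cccs3)no2)cc1` gives 10400 nM;
compound 3 `O=C(NO)c1ccc(CNCc2nc(-c3ccc(F)cc3)no2)cc1` gives 9120 nM.

All three were tested in a functional assay on MDA-MB-231 cells (Homo sapiens) for inhibition, read by MTT assay, with a stated time of 72 h; on this read-out lower numbers stand for stronger inhibition and higher numbers for weaker inhibition. Compound 1 is the reference point. Swapping one ring for another on the aromatic carbon, (thiophen-2-yl in place of 4-fluorophenyl on an aromatic carbon), gives a 3.5-fold higher number from compound 1 to compound 2 (0.55 log units; beyond the scatter). Changing the amide end instead, (hydroxy in place of 2-aminophenyl on an amide-type nitrogen), gives a 3.1-fold higher number from compound 1 to compound 3 (0.49 log units; beyond the scatter). The values of compound 2 and compound 3 lie within the scatter of each other, so no order between them can be read.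

Compound 4 `O=C(NO)c1ccc(CNCc2nc(-c3cccs3)no2)cc1` has not yet been measured in this assay. It differs from compound 3 by thiophen-2-yl in place of 4-fluorophenyl on an aromatic carbon. Going by the values given here, this is the same change as the one from compound 1 to compound 2, made on a different core; how the two cores differ is told by hydroxy in place of 2-aminophenyl on an amide-type nitrogen, and the place description is the same word for word. Because the earlier step read a 3.5-fold higher number from compound 1 to compound 2 (0.55 log units; beyond the scatter), a step of similar size is expected here, so the estimated change is a 3.1-fold higher number from compound 3 to compound 4 (0.49 log units; beyond the scatter). Compound 4 is therefore expected to give about 28000 nM, most likely between 9000 nM and 90000 nM, in this assay.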

Compound 4, half-maximal inhibitory concentration: 23900 nM
For compound 4 the middle estimate is 1.2-fold (0.07 log units) above the measured one; the range from low to high includes it.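

In this assay, thiophen-2-yl in place of 4-fluorophenyl gives a 2.6-fold higher number from compound 3 to compound 4 (0.42 log units; beyond the scatter), so the change raises the number on this core as well, and the size of the step carries over from the core of compound 1: the same change on two cores in this assay, a 3.5-fold higher number (0.55 log units; beyond the scatter) from compound 1 to compound 2 and a 2.6-fold higher number (0.42 log units; beyond the scatter) from compound 3 to compound 4, 1.3-fold (0.13 log units) apart, within the scatter of two such steps. Read the other way, hydroxy in place of 2-aminophenyl gives a 2.3-fold higher number from compound 2 to compound 4 (0.36 log units; beyond the scatter), so this change also keeps its size whichever of the two rings is present, and the two changes behave as independent steps across these four compounds: the same change on two cores in this assay, a 3.1-fold higher number (0.49 log units; beyond the scatter) from compound 1 to compound 3 and a 2.3-fold higher number (0.36 log units; beyond the scatter) from compound 2 to compound 4, 1.3-fold (0.13 log units) apart, within the scatter of two such steps. This rests on just two cores and one pair of rings in a single cell read-out, so it shows that the steps carried over here, but neither that they would carry over to other groups nor why the number rises.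

The compounds shown leave open how a methoxy group in place of the fluorine on the phenyl ring would fit this pattern. They also leave open whether a carboxylic acid at the amide end would follow it.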